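From bromo to benzyl on the shared core

The source may report more compounds than this note shows. Statements on the series, on what has been measured and on what is new or still open speak of the compounds shown alone.

Measured so far in a physicochemical assay for solubility, read by HPLC, at pH 7.4 (a higher number here means a more soluble compound, a lower number a less soluble compound), for two compounds:
Compound 1 `Cc1[nH]c2ccccc2c(=O)c1Cc1ccccc1` gives 10000 nM
Compound 2 `COc1ccc2[nH]c(C)c(Br)c(=O)c2c1` gives > 20000 nM as a limit

Compound 2 gives > 20000 nM in this assay and that is a limit of the assay, not a number. Compound 3 `COc1ccc2[nH]c(C)c(Cc3ccccc3)c(=O)c2c1` has yet to be measured. It keeps the rest of compound 2 but carries benzyl in place of bromo on an aromatic carbon and so gains one six-membered aromatic ring of carbon only. Going by the values given here, no measured pair shows this change alone. The estimated at least 2.5-fold lower number from compound 2 to compound 3 (0.39 log units; beyond the scatter) runs downward and beyond the scatter. That expectation rests on compound 1, which also carries a benzyl and gives 10000 nM in this assay as a measured number. In this assay the estimate for compound 3 is 8000 nM with a range from 3000 nM to 20000 nM expected.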

Compound 3, solubility: 2000 nM
The estimate for compound 3 lay 4.0-fold (0.60 log units) above the measured number, outside the stated range (below it).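

Benzyl in place of bromo on an aromatic carbon now has a reading in this assay, and the number falls: an at least 10-fold lower number from compound 2 to compound 3 (1.00 log units; beyond the scatter). For compound 2 the reading is a limit of the assay and not a number, so this step has no upper end: the limit of > 20000 nM in this assay, at which 1 of the 3 values shown sits. With benzyl present in both compounds, methoxy in place of hydrogen on an aromatic carbon also goes with a lower number in this assay, a second change at a different place on the shared core: a 5.0-fold lower number from compound 1 to compound 3 (0.70 log units; beyond the scatter).

The compounds shown leave open how a group such as an ethyl chain or an amine would read in the place of benzyl, two atoms from the ring nitrogen. They also leave open whether methoxy goes with a step of similar size when bromo stands in that place, or how a carboxylic acid would read in the place of methoxy.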